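Swapping trifluoromethyl for fluoro on a second aromatic ring

The compounds below may be only part of what the source reports. "The series", "measured", "known", "first", "only" and "open" are said of these compounds alone.

Measured so far in an assay on cells for inhibition of histone deacetylase 4 (Homo sapiens), read by fluorescence, with a stated time of 30 min; on this read-out lower numbers stand for stronger inhibition and higher numbers for weaker inhibition:
compound 1 `O=C1NC(=O)/C(=C\c2ccc(OCC(=O)N3N=C(c4ccccc4)CC3c3ccc(C(F)(F)F)cc3)cc2)S1` gives 1000 nM;
compound 2 `O=C1NC(=O)/C(=C\c2ccc(OCC(=O)N3N=C(c4ccccc4)CC3c3ccc(F)cc3)cc2)S1` gives 1700 nM;
compound 3 `O=C1NC(=O)/C(=C\c2ccc(OCC(=O)N3N=C(c4ccc(F)cc4)CC3c3ccc(C(F)(F)F)cc3)cc2)S1` gives 1300 nM.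

All three share one core; compound 3 differs from compound 1 only by fluoro in place of hydrogen on an aromatic carbon, a step of a 1.3-fold higher number from compound 1 to compound 3 (0.11 log units; within the scatter). Compound 2 differs from compound 1 by fluoro in place of trifluoromethyl on an aromatic carbon, which gave a 1.7-fold higher number from compound 1 to compound 2 (0.23 log units; within the scatter). Among the compounds with values here, compound 4 `O=C1NC(=O)/C(=C\c2ccc(OCC(=O)N3N=C(c4ccc(F)cc4)CC3c3ccc(F)cc3)cc2)S1` is not yet measured; it differs from compound 3 by fluoro in place of trifluoromethyl on an aromatic carbon, the same change as the one from compound 1 to compound 2, at the same place. Within the data shown here, because that earlier step was a 1.7-fold higher number from compound 1 to compound 2 (0.23 log units; within the scatter), a similar small step is expected here, a 1.7-fold higher number from compound 3 to compound 4 (0.23 log units; within the scatter), resting on the single earlier example. Compound 4 is therefore estimated at 2200 nM, with a range from 1200 nM to 4000 nM.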

Compound 4, half-maximal inhibitory concentration: 1400 nM
Compound 4: middle estimate off by 1.6-fold (0.20 log units), on the high side, and the stated range covers the measured number.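

In this assay, fluoro in place of trifluoromethyl gives a 1.1-fold higher number from compound 3 to compound 4 (0.03 log units; within the scatter), and this change stays small on both cores: the same change on two cores in this assay, a 1.7-fold higher number (0.23 log units; within the scatter) from compound 1 to compound 2 and a 1.1-fold higher number (0.03 log units; within the scatter) from compound 3 to compound 4, 1.6-fold (0.20 log units) apart, within the scatter of two such steps. Fluoro in place of hydrogen gives a 1.2-fold lower number from compound 2 to compound 4 (0.08 log units; within the scatter), and this change also stays small on both cores: the same change on two cores in this assay, a 1.3-fold higher number (0.11 log units; within the scatter) from compound 1 to compound 3 and a 1.2-fold lower number (0.08 log units; within the scatter) from compound 2 to compound 4, 1.6-fold (0.20 log units) apart, within the scatter of two such steps. Both changes therefore carry from one core to the other within these four compounds, but with every step inside the scatter, the data show neither a real effect of either change nor any true difference between the cores.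

The only groups shown at these places are hydrogen, fluoro and trifluoromethyl. As far as these compounds go, how a chloro group, a methoxy group or an amine would behave there remains open.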